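The source may hold more compounds than are shown below. What is called first, only, known or untested is meant among the compounds shown, and "the series" means these compounds.

Measured in a functional assay on A2780 cells (Homo sapiens) for antiproliferative activity, read by resazurin assay, with a stated time of 72 h; a higher number here means a weaker inhibitor, a lower number a stronger inhibitor:

Compound 1 `CN(Cc1ccc(Br)cc1)C(=O)c1cc2c(Cc3ccccc3)n[nH]c2cc1O`: 2800 nM
Compound 2 `Cc1ccc(CN(C)C(=O)c2cc3c(Cc4ccccc4)n[nH]c3cc2O)cc1`: 6900 nM

Of these two, compound 2 stands at the higher number and is therefore the weaker inhibitor. Among the measured compounds shown here, the one measured step, a 2.5-fold higher number from compound 1 to compound 2 (0.39 log units; beyond the scatter), is modest, and it arises from methyl in place of bromo on an aromatic carbon.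

The next compound, compound 3 `CCOc1ccc(CN(C)C(=O)c2cc3c(Cc4ccccc4)n[nH]c3cc2O)cc1`, changes that same place again. Its difference from compound 2 is ethoxy in place of methyl on an aromatic carbon, para to a large group. For the measured compounds named here, no ethoxy compound has been measured, so the single step bears on this change only indirectly. It shows that replacing the group at this place can move the number by a modest amount, and that the methyl compound sits at the higher end so far. A step of similar or smaller size is therefore expected in this assay, more likely toward a lower number, though it may stay within the scatter.

The estimated step is a 1.5-fold lower number from compound 2 to compound 3 (0.19 log units; within the scatter). For compound 3 the expected value is 4500 nM, with an estimated range from 1800 nM to 11000 nM.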

Compound 3, half-maximal inhibitory concentration: 3200 nM
The estimate for compound 3 lay 1.4-fold (0.15 log units) above the measured number, within the range that was stated.
By their numbers in this assay, from the lowest: compounds 1 and 3 (each within the scatter of the next); then compound 2.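

In this assay, the change from 4-methylbenzyl to 4-ethoxybenzyl gives a 2.2-fold lower number from compound 2 to compound 3 (0.33 log units; beyond the scatter) and so reverses most of what the earlier step from bromo to methyl had lost, showing that the number at this place, para to a large group, does not only rise on leaving bromo. The comparison with bromo gives a 1.1-fold higher number from compound 1 to compound 3 (0.06 log units; within the scatter) and leaves the two groups indistinguishable in this assay, although ethoxy brings an oxygen and a short chain into the position; among these three compounds, compound 2 with its methyl is the weakest inhibitor, with both of its steps beyond the scatter. Nothing at hand explains why methyl stands apart from bromo and ethoxy, or why ethoxy and bromo end up so close.

The three compounds leave open how a longer chain such as butoxy, an amine or a carboxylic acid would behave at this place, and what the ring would give with only hydrogen there. They also leave open whether the same ordering of methyl, ethoxy and bromo would hold at any other place on that ring.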